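Moving the sulfonyl attachment around a quinoline ring

The source may report more compounds than this note shows. Statements on the series, on what has been measured and on what is new or still open speak of the compounds shown alone.

Measured so far:
compound 1, `COc1ccc2c(c1)c(C1=CCNCC1)cn2S(=O)(=O)c1cnc2ccccc2c1`: 8 nM
compound 2, `COc1ccc2c(c1)c(C1=CCNCC1)cn2S(=O)(=O)c1ccc2ncccc2c1`: 14 nM

Both compounds were tested in an assay on HEK293 cells for displacement of a labelled ligand from 5-hydroxytryptamine receptor 6 (Homo sapiens), read by scintillation counting; a lower number here means a stronger inhibitor, a higher number a weaker inhibitor. Compound 2 sits at one end of the two numbers shown, but its distance from compound 1 is within the scatter: the step of a 1.8-fold higher number from compound 1 to compound 2 (0.24 log units; within the scatter).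

Compound 3, `COc1ccc2c(c1)c(C1=CCNCC1)cn2S(=O)(=O)c1ccc2cccnc2c1`, has not yet been measured. It differs from compound 2 in a single place: quinolin-7-yl in place of quinolin-6-yl on a sulfonyl sulfur. For the measured compounds named here, the one measured step that bears on this, a 1.8-fold higher number from compound 1 to compound 2 (0.24 log units; within the scatter), also swapped the point at which the quinoline is joined to the sulfonyl sulfur, and it stayed within the scatter. Going by the values given here, only one such step is known, so the expectation rests on thin ground.

On that basis no step beyond the scatter is expected for compound 3 in this assay, and its estimated step is no change at the digits printed from compound 2 to compound 3 (within the scatter). Compound 3 is therefore estimated at 14 nM, with a range from 5 nM to 40 nM.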

Compound 3, inhibition constant: 2 nM
Compound 3: middle estimate off by 7.0-fold (0.85 log units), on the high side; measured number below the stated range.
By their numbers in this assay, from the lowest: compound 3; then compounds 1 and 2 (each within the scatter of the next).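

Moving the attachment point on the quinoline can matter after all: in this assay, quinolin-7-yl in place of quinolin-6-yl on the sulfonyl sulfur gives a 7.0-fold lower number from compound 2 to compound 3 (0.85 log units; beyond the scatter) and quinolin-7-yl in place of quinolin-3-yl gives a 4.0-fold lower number from compound 1 to compound 3 (0.60 log units; beyond the scatter) as well. Both steps lie beyond the scatter, while the earlier step between the other two attachment points did not, so the same atoms joined differently can separate these compounds, and compound 3 has the lowest number of the three. Nothing measured here explains why quinolin-7-yl stands apart.

The compounds shown leave open how quinolin-5-yl or quinolin-8-yl on the sulfonyl sulfur would compare. They also leave open whether the ring nitrogen of quinolin-7-yl matters at all, which the all-carbon naphthalen-2-yl group would test.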